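The source may hold more compounds than are shown below. What is called first, only, known or untested is meant among the compounds shown, and "the series" means these compounds.

In an ADME assay on BJ cells (Homo sapiens) for cytotoxicity, read by CellTiter-Glo, with a stated time of 72 h (a higher number here means that more compound is needed for the effect, a lower number that less compound is needed), compound 1 (`CC1=C2CC(C)(C)/C=C/C/C(C)=C\C3=C[C@H](C)C[C@]3(O2)C1=O`) gives 26000 nM and compound 2 (`CC1=C2CC(C)(C)/C=C/C(=O)/C(C)=C\C3=C[C@H](C)C[C@]3(O2)[C@@]1(O)C#N`) gives 26000 nM as well. Compound 3 (`CO[C@H]1[C@@H]2C(=O)/C(C)=C\C3=C[C@H](C)C[C@@]34O[C@]2(CC1(C)C)[C@@H](C)C4=O`) also gives 26000 nM and so stands level with both, although the three structures differ from one another in more than one place. Compound 4 (`C/C1=C/C2=C[C@H](C)C[C@@]23O[C@]2(CC(C)(C)[C@@H](Nc4ccccc4)[C@@H]2C1=O)[C@@H](C)C3=O`) departs from compound 3 by a single change, anilino in place of methoxy on a saturated ring carbon. Among the measured compounds shown here, no measured pair differs in only one place, so the data give no direct measure of what such a swap does. For the measured compounds named here, the three identical readings offer the only guide, and they point to a small step at most. The expectation is a modest move toward less compound needed, possibly none beyond the scatter, starting from compound 3 at 26000 nM in the same test. The estimate amounts to a 1.4-fold lower number from compound 3 to compound 4 (0.16 log units; within the scatter) as the expected change. Compound 4 is expected at 18000 nM with 7000 nM to 30000 nM as the estimated range.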

Compound 4, half-maximal effective concentration: 12600 nM
Compound 4: middle estimate off by 1.4-fold (0.15 log units), on the high side; measured number inside the range.
By their numbers in this assay, from the lowest: compound 4; then compounds 1, 2 and 3 (each within the scatter of the next).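

In this assay, among the compounds shown here, the exchange of methoxy for anilino gives the first reading of a single change in this set (a 2.1-fold lower number from compound 3 to compound 4 (0.31 log units; beyond the scatter)), a modest step that lies beyond the scatter. It shows that this saturated ring carbon, on a five-membered non-aromatic ring within the system of four rings, can carry the larger anilino group, with its aromatic ring and hydrogen-bond donor, and that the number still moves toward less compound needed. Nothing available explains the step, and one pair cannot say which part of the anilino group goes with it.

The compounds shown leave open whether the aromatic ring or the nitrogen hydrogen goes with the lower number. A cyclohexylamino, dimethylamino or phenoxy group on the same carbon would bear on that question.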